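Trifluoromethyl to fluoro: notes on compound 3

A few compounds are considered here, and "the series" means these few. Any claim that something is new, unique, unknown or untested is made for them only; others in the source may bear on it.

Compound 1 `C#Cc1cccc(Nc2ncnc3cc(OC)c(OCCCN4CCNCCNCCNCC4)cc23)c1` gives 28600 nM
Compound 2 `COc1cc2ncnc(Nc3cccc(C(F)(F)F)c3)c2cc1OCCCN1CCNCCNCCNCC1` gives 15700 nM

Going by the values given here, both values were obtained in a functional assay on A549 cells (Homo sapiens) for antiproliferative activity, read by MTT assay, with a stated time of 72 h (on this read-out lower numbers stand for stronger inhibition and higher numbers for weaker inhibition), and are the only measurements so far. Compound 2 lies within the scatter of compound 1, so the two numbers do not separate these compounds. Compound 3 `COc1cc2ncnc(Nc3cccc(F)c3)c2cc1OCCCN1CCNCCNCCNCC1` has not yet been measured. It differs from compound 2 by fluoro in place of trifluoromethyl on an aromatic carbon and the change is fluoro in place of trifluoromethyl on an aromatic carbon, meta to a large group.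

Among the compounds with values here, the one measured step bearing on this is a 1.8-fold lower number from compound 1 to compound 2 (0.26 log units; within the scatter) and it is also a replacement on an aromatic carbon. Within the data shown here, it is a single small step, and no measured compound carries fluoro at this place. Among the measured compounds shown here, with only that guide, no step beyond the scatter is expected in this assay and no firm direction can be given. The expected change is a 1.3-fold higher number from compound 2 to compound 3 (0.11 log units; within the scatter) and remains a rough estimate. Compound 3 is estimated at 20000 nM with an expected range from 9000 nM to 42000 nM for the measurement.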

Compound 3, half-maximal inhibitory concentration: > 50000 nM
Compound 3: a limit, no number (the forecaster's own chance of this, stated with the estimate: 5%); middle value at least 2.5-fold (0.39 log units) from the limit.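

In this assay compound 3 gives > 50000 nM, which is a limit of the assay and not a number, so the size of any step to it has only a floor: the limit of > 50000 nM in this assay, at which 1 of the 3 values shown sits.

The earlier pair did not separate ethynyl from trifluoromethyl at this aromatic carbon, but the series now shows that the position is not indifferent to what it carries: an at least 3.1-fold higher number from compound 2 to compound 3 (0.50 log units; beyond the scatter). The comparison with ethynyl is less firm, since it reads an at least 1.7-fold higher number from compound 1 to compound 3 (0.24 log units; that floor lies within the scatter), and so only the trifluoromethyl to fluoro change is established as a real loss of activity on this read-out.

Going by these compounds, how large that loss is stays open, as does whether it belongs to fluoro alone or extends to other replacements at this place. A chloro, a methoxy or an amine on the same aromatic carbon, with the shared core and side chain unchanged, would show whether the values follow any order across groups or whether ethynyl and trifluoromethyl are simply two groups that keep a measurable value in this assay.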